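Methyl for methoxy on the phenyl of the thiazole series

The source may report more compounds than this note shows. Statements on the series, on what has been measured and on what is new or still open speak of the compounds shown alone.

Measured compounds:
compound 1 `CCn1nnc(-c2sc(-c3ccccc3O)nc2O)n1` — 24 nM
compound 2 `CCn1nnc(-c2sc(-c3ccccc3OC)nc2O)n1` — 2790 nM

Within the data shown here, in an assay on HEK293 cells for inhibition of transient receptor potential cation channel subfamily M member 8 (Homo sapiens), read by FLIPR, with stated times of 5 min and 3 min (a higher number here means a weaker inhibitor, a lower number a stronger inhibitor), compound 2 gives 2790 nM, the highest of the two numbers so far; the only neighbour is compound 1, which gives 24 nM. Among the measured compounds shown here, the single measured step, a 120-fold higher number from compound 1 to compound 2 (2.07 log units; beyond the scatter), shows that capping the ring oxygen with a methyl costs a great deal in this assay.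

Compound 3 `CCn1nnc(-c2sc(-c3ccccc3C)nc2O)n1` is not yet measured. Relative to compound 2 the change is methyl in place of methoxy on an aromatic carbon. For the measured compounds named here, no measured step covers this exact exchange. The step from compound 1 to compound 2 bears on it only indirectly: it shows that the series loses potency once the hydroxyl of compound 1 is gone, and compound 3, like compound 2, carries no hydroxyl at this position. The expectation therefore rests on compound 2 rather than compound 1, with the methyl treated as a near-neutral replacement for methoxy: the estimated step is a 1.1-fold higher number from compound 2 to compound 3 (0.03 log units; within the scatter), not clearly beyond the scatter in either direction. Compound 3 is expected to give about 3000 nM in this assay, with a plausible range of 800 nM to 12000 nM.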

Compound 3, half-maximal inhibitory concentration: 60 nM
The estimate for compound 3 lay 50-fold (1.70 log units) above the measured number, outside the stated range (below it).
By their numbers in this assay, from the lowest: compound 1; then compound 3; then compound 2.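

Working notes on the ortho position: in this assay, removing the hydroxyl does not by itself produce the weak number of compound 2, since the methyl analogue also lacks that hydroxyl and still recovers most of the potency (a 47-fold lower number from compound 2 to compound 3 (1.67 log units; beyond the scatter)). Within these three compounds, the large loss therefore goes with the methoxy group rather than with the absence of a hydrogen-bond donor, so the step first read as a penalty for capping the oxygen is better read as a penalty specific to methoxy at this place. Hydroxy still holds a modest edge over methyl (a 2.5-fold higher number from compound 1 to compound 3 (0.40 log units; beyond the scatter)), but no evidence on the series accounts for either step.

Still open, going by these compounds, is how an ethyl group, a chlorine atom or an amine at this position would rank against methyl, hydroxy and methoxy, and whether an ethoxy group would carry the same penalty as methoxy. Also open, on these data alone, is whether this ranking would hold if the ethyl chain on the shared core were exchanged for a longer chain.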